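A Cyclopentyl Ring Replaces 1-Hydroxy-1-methylethyl in Compound 3

The source may report more compounds than this note shows. Statements on the series, on what has been measured and on what is new or still open speak of the compounds shown alone.

In an ADME assay on HepG2 cells (Homo sapiens) for cytotoxicity, read by MTT assay, with a stated time of 72 h (a lower number here means that less compound is tolerated, a higher number that more compound is tolerated), compound 3 (`CC(C)(O)C#Cc1cc(Cl)cn2c([N+](=O)[O-])c(CS(=O)(=O)c3ccccc3)nc12`) gives > 62500 nM, which is a limit and not a number. Compound 1 (`COc1cccc(C#Cc2cc(Cl)cn3c([N+](=O)[O-])c(CS(=O)(=O)c4ccccc4)nc23)c1`) gives > 3900 nM, also a limit. Compound 2 (`O=[N+]([O-])c1c(CS(=O)(=O)c2ccccc2)nc2c(C#Cc3ccc(CO)cc3)cc(Cl)cn12`) gives > 15600 nM, again a limit. Compound 4 (`O=[N+]([O-])c1c(CS(=O)(=O)c2ccccc2)nc2c(C#CC3(O)CCCC3)cc(Cl)cn12`) carries 1-hydroxycyclopentyl in place of the 1-hydroxy-1-methylethyl of compound 3, on a triple-bonded carbon: 1-hydroxycyclopentyl in place of 1-hydroxy-1-methylethyl on a triple-bonded carbon. Three measured steps change the group at this same place: a step that the two limits leave unreadable from compound 1 to compound 2, a step that the two limits leave unreadable from compound 1 to compound 3 and a step that the two limits leave unreadable from compound 2 to compound 3. None of them offers a size to carry over, so the expectation in this assay can only be a cautious one. The expected change is an at least 2.0-fold lower number from compound 3 to compound 4 (0.31 log units; beyond the scatter), a modest move toward less compound being tolerated, and another limit is more likely than a number. For compound 4 the estimated value is 30000 nM, with an expected range from 8000 nM to 90000 nM.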

Compound 4, half-maximal cytotoxic concentration: > 31300 nM
Compound 4 gave a limit, no number; the forecaster's own chance of this, stated with the estimate: 85%; middle value at least 1.0-fold (0.01 log units) from the limit.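

Compound 4 gives > 31300 nM, which is a limit and not a number. Going by these compounds alone, compound 1, compound 2 and compound 3 also gave only limits, and no step between any of them and compound 4 can be read. The compounds shown leave open the concentration at which any of the four harms these cells.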